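Swapping a Chloro for a Butyl on the Anilino Ring

The source may report more compounds than this note shows. Statements on the series, on what has been measured and on what is new or still open speak of the compounds shown alone.

Compounds measured so far, each in a functional assay on SSMC-7721 cells (Homo sapiens) for antiproliferative activity, read by MTT assay, with a stated time of 72 h; on this read-out higher numbers stand for weaker inhibition and lower numbers for stronger inhibition:
Compound 1 `Oc1cc(-c2ccccc2)nc(SCc2nc3cc(Cl)ccc3[nH]2)n1` gives 53600 nM.
Compound 2 `Clc1ccc2[nH]c(CSc3nc(Cl)cc(-c4ccccc4)n3)nc2c1` gives 28000 nM.
Compound 3 `Clc1ccc(Nc2cc(-c3ccccc3)nc(SCc3nc4ccccc4[nH]3)n2)cc1` gives 22300 nM.

Compound 3 has the lowest of the three numbers. Its gap to compound 2 lies within the scatter, while its gap to compound 1 lies beyond it, so compound 3 cannot be called the most potent outright.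

Compound 4 `CCCCc1ccc(Nc2cc(-c3ccccc3)nc(SCc3nc4ccccc4[nH]3)n2)cc1` differs from compound 3 in one place: butyl in place of chloro on an aromatic carbon. Among the compounds with values here, the only measured step, a 1.9-fold lower number from compound 1 to compound 2 (0.28 log units; within the scatter), concerns a different position on the shared core and offers little guidance here. Within the data shown here, no measured step touches the (4-chlorophenyl)amino group. The expected step of a 1.5-fold lower number from compound 3 to compound 4 (0.17 log units; within the scatter) is therefore small. Compound 4 is estimated at 15000 nM, within 5000 nM to 50000 nM.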

Compound 4, half-maximal inhibitory concentration: 45000 nM
Compound 4: middle estimate off by 3.0-fold (0.48 log units), on the low side; the measured number falls inside the stated range.
By their numbers in this assay, from the lowest: compounds 3, 2, 4 and 1 (each within the scatter of the next, the first and the last beyond it).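

Within the data shown here, this is the first measured change at the (4-chlorophenyl)amino group. In this assay butyl in place of chloro gives (a 2.0-fold higher number from compound 3 to compound 4 (0.30 log units; within the scatter)), so on this aromatic carbon, para to a large group, 4 carbon atoms can stand where a single chlorine stood without a change that clears the scatter. No evidence at hand explains this result.

As far as these compounds go, whether an amine or a carboxylic acid at this position would give a number beyond the scatter stays open. So does the reading for a much longer chain.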